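Carboxy to hydrogen on the furan ring

The source may hold more compounds than are shown below. What is called first, only, known or untested is meant among the compounds shown, and "the series" means these compounds.

Measured so far in an ADME assay on microsomes from liver (Rattus norvegicus) for metabolic stability (on this read-out lower numbers stand for a shorter-lived compound and higher numbers for a longer-lived compound), are:
- compound 1 `Cn1nc2c(=O)n(CC3(O)CCN(Cc4ccc(-c5ccco5)cc4Cl)CC3)cnc2c1-c1ccc(C2(N)CC2)cc1` with 0.617 h
- compound 2 `Cn1nc2c(=O)n(CC3(O)CCN(Cc4ccc(-c5ccc(C(=O)O)o5)cc4Cl)CC3)cnc2c1-c1ccc(CN)cc1` with 1.25 h

Compound 2 stands highest of the two numbers, and the gap down to compound 1 lies beyond the usual scatter. Compound 3 `Cn1nc2c(=O)n(CC3(O)CCN(Cc4ccc(-c5ccco5)cc4Cl)CC3)cnc2c1-c1ccc(CN)cc1` awaits measurement. Its structure has hydrogen in place of carboxy on an aromatic carbon (5-carboxyfuran-2-yl to furan-2-yl).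

Among the compounds with values here, no measured pair isolates this change. Compound 1 (0.617 h) carries the same furan-2-yl group but also differs from compound 3 elsewhere, so it offers only a rough guide. A lower number is expected in this assay, with an estimated step of a 2.0-fold lower number from compound 2 to compound 3 (0.30 log units; within the scatter) near the edge of the scatter. The expected half-life of compound 3 is 0.62 h, with an estimated range of 0.3 h to 1.3 h for repeat measurements.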

Compound 3, half-life: 2.37 h
Compound 3: the middle estimate sits 3.8-fold (0.58 log units) below what was measured, and the stated range ends below it.
By their numbers in this assay, from the lowest: compound 1; then compounds 2 and 3 (each within the scatter of the next).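

Carboxy and hydrogen on this aromatic carbon of the furan ring, next to the ring oxygen, are not separated in this assay: the exchange gives a 1.9-fold higher number from compound 2 to compound 3 (0.28 log units; within the scatter) and stays within the scatter, so the half-life does not resolve the two groups at this position. Within the data shown here, with furan-2-yl held constant, aminomethyl in place of 1-aminocyclopropyl gives a 3.8-fold higher number from compound 1 to compound 3 (0.58 log units; beyond the scatter) and lies beyond the scatter, making it the only one-place step here that can be read as a real difference. Nothing on hand explains either step.

As far as these compounds go, whether a primary amide or a methyl ester at this furan position would also stay within the scatter of compound 3 remains open. Also open, from the compounds shown here alone, is whether carboxy and hydrogen remain unresolved when 1-aminocyclopropyl replaces aminomethyl.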